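The source may report more compounds than this note shows. Statements on the series, on what has been measured and on what is new or still open speak of the compounds shown alone.

Compound 1 `c1ccc(CNCCCCN(C[C@H]2Cc3ccccc3CN2)[C@H]2CCCc3cccnc32)cc1` reaches only the limit > 30000 nM in a functional assay on cells for agonist activity at C-X-C chemokine receptor type 4 (Homo sapiens), read by fluorescence and calcium flux, with a stated time of 90 s; a higher number here means that more compound is needed for the effect, a lower number that less compound is needed.
Compound 2 `c1ccc2c(c1)CN[C@@H](CN(CCCCNCC1CCNCC1)[C@H]1CCCc3cccnc31)C2` reaches only the limit > 30000 nM in this assay.
Compound 3 `c1ccc2c(c1)CN[C@@H](CN(CCCCNCC1CCSCC1)[C@H]1CCCc3cccnc31)C2` reaches only the limit > 30000 nM in this assay.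

Compound 3 therefore stands at a limit, not at a number. the limit of > 30000 nM in this assay, at which 3 of the 3 values shown sit, holds for every value shown. The steps a step that the two limits leave unreadable from compound 1 to compound 2, a step that the two limits leave unreadable from compound 1 to compound 3 and a step that the two limits leave unreadable from compound 2 to compound 3 cannot be sized, as both ends of each sit at that limit. Compound 4 `O=S1(=O)CCC(CNCCCCN(C[C@H]2Cc3ccccc3CN2)[C@H]2CCCc3cccnc32)CC1` differs from compound 3 by 1,1-dioxothian-4-yl in place of thian-4-yl on a saturated chain carbon bound to an amine nitrogen. Within the data shown here, no measured step gives a readable size for this change, and no measured compound escapes the limit. Compound 4 is thus expected to stay at the limit as well, with an expected value of 30000 nM between 10000 nM and 100000 nM. The expected step is a number no higher from compound 3 to compound 4 (the limit leaves the size open), which is no change beyond the scatter.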

Compound 4, half-maximal effective concentration: > 30000 nM
Compound 4 gave a limit, no number (the forecaster's own chance of this, stated with the estimate: 85%); the middle value lies on the limit itself.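

Among these compounds, compound 4, like compound 1, compound 2 and compound 3, gives only a limit, so no step among them can be read: the limit of > 30000 nM in this assay, at which 4 of the 4 values shown sit. The compounds shown leave open whether any group in this place gives a measurable value in this assay.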